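Replacing 1H-imidazol-1-yl with dimethylamino in compound 2

The compounds below may be only part of what the source reports. "The series", "measured", "known", "first", "only" and "open" are said of these compounds alone.

- compound 1 `CN(C)CC#CCN1CCNC1=O` gives 9.7 mg/kg
- compound 2 `CN1CCN(CC#CCn2ccnc2)C1=O` gives 1.4 mg/kg
- compound 3 `Cc1cncn1CC#CCN1CCN(C)C1=O` gives > 100 mg/kg

In a functional assay on the whole organism for agonist activity, with Mus musculus as the target (a lower number here means that less compound is needed, a higher number that more compound is needed for the effect), compound 2 has the lowest number of the measured compounds, with compound 1 higher. The entry for compound 3 is a limit of the assay and not a number. The change to compound 4 `CN(C)CC#CCN1CCN(C)C1=O` is dimethylamino in place of 1H-imidazol-1-yl on a saturated chain carbon bound to a triple-bonded carbon and it removes the ring altogether. Within the data shown here, the only measured step, an at least 71-fold higher number from compound 2 to compound 3 (1.85 log units; beyond the scatter), is large, but it alters the group that leaves here, so it sets no size for this change. Compound 1 also carries dimethylamino and gives 9.7 mg/kg, which points to a moderate rise in this assay. The expected step is a 4.3-fold higher number from compound 2 to compound 4 (0.63 log units; beyond the scatter), towards a higher number. Compound 4 is estimated at 6 mg/kg, with an expected range from 1.5 mg/kg to 30 mg/kg.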

Compound 4, dose for half-maximal effect: 0.54 mg/kg
Beside the measured number, compound 4's estimate is 11-fold (1.05 log units) above it, and the stated range ends above it.
By their numbers in this assay, from the lowest: compound 4; then compound 2; then compound 1. At a limit, above all of these: compound 3.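

In this assay, an aromatic ring is not needed on the saturated chain carbon bound to a triple-bonded carbon: dimethylamino, which has no ring, gives a 2.6-fold lower number from compound 2 to compound 4 (0.41 log units; beyond the scatter). With dimethylamino held in place, the methyl on the amide-type nitrogen in the ring also matters, giving an 18-fold lower number from compound 1 to compound 4 (1.25 log units; beyond the scatter). Together, these steps separate two changes that compound 1 and compound 2 could not, as those compounds differ in both places. On these data alone, how a ring amine such as pyrrolidin-1-yl would behave at this position remains open. The data shown offer no measured reason for either step.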